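Ring substituent change on a shared core: forecast for compound 4

The compounds below may be only part of what the source reports. "The series", "measured", "known", "first", "only" and "open" are said of these compounds alone.

Going by the values given here, compound 3 `COc1ccc(/C=C2\S/C(=N\c3ccc(F)cc3)N(C)C2=O)cc1` is the only member of this small set to give a number in a functional assay on HCT-116 cells (Homo sapiens) for antiproliferative activity, read by MTT assay, with a stated time of 72 h; a higher number here means a weaker inhibitor, a lower number a stronger inhibitor: compound 3 gives 13300 nM. Its two neighbours sit at a limit of the assay. Compound 1 `COc1ccc(/C=C2\S/C(=N\c3ccc(C(C)(C)C)cc3)N(C)C2=O)cc1` reaches only > 100000 nM in this assay, a limit rather than a number. Compound 2 `COc1ccc(/C=C2\S/C(=N\c3ccccc3)N(C)C2=O)cc1` likewise gives > 100000 nM, again a limit. The steps toward compound 3 are therefore read in one direction only: an at least 7.5-fold lower number from compound 1 to compound 3 (0.87 log units; beyond the scatter) and an at least 7.5-fold lower number from compound 2 to compound 3 (0.87 log units; beyond the scatter), both bounded by the limit of > 100000 nM in this assay, at which 2 of the 3 values shown sit. Compound 4 `COc1ccc(/C=C2\S/C(=N\c3c(C)cccc3C)N(C)C2=O)cc1` differs from compound 3 in a single place: 2,6-dimethylphenyl in place of 4-fluorophenyl on a double-bonded nitrogen. Among the compounds with values here, the fluoro that alone accompanied a readable number is gone, and the group that enters resembles neither the tert-butyl of compound 1 nor the hydrogen of compound 2, so no measured step covers it directly. Compound 4 is expected to return toward the limit, with an estimated step of a 6.0-fold higher number from compound 3 to compound 4 (0.78 log units; beyond the scatter). The value of compound 4 in this assay is estimated at 80000 nM, within the range 15000 nM to 300000 nM.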

Compound 4, half-maximal inhibitory concentration: > 100000 nM
Compound 4 was reported as a limit; the forecaster's own chance of this, stated with the estimate: 55%; middle value at least 1.2-fold (0.09 log units) from the limit.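

In this assay, replacing 4-fluorophenyl with 2,6-dimethylphenyl on the double-bonded nitrogen gives an at least 7.5-fold higher number from compound 3 to compound 4 (0.87 log units; beyond the scatter), so a third group at this position, after those of compound 1 and compound 2, fails to give a readable number. The step from compound 2 to compound 4 cannot be read, as both values are limits, so phenyl and 2,6-dimethylphenyl cannot be placed in any order. Among the compounds shown, the 4-fluorophenyl of compound 3 remains the only group here that gives a number, and the limit now covers all the others: the limit of > 100000 nM in this assay, at which 3 of the 4 values shown sit.

The compounds shown leave open whether a chloro or a methoxy group in place of the fluoro of compound 3 would also give a number. They also leave open how a 2,6-difluorophenyl group on this nitrogen would read.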